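The source may report more compounds than this note shows. Statements on the series, on what has been measured and on what is new or still open speak of the compounds shown alone.

Working notes on the series. Compound 1 `Oc1ccc(-c2cc(-c3ccc(F)cc3)cc(-c3ccccc3O)n2)cc1` carries a fluoro group and two 4-hydroxyphenyl groups. In a functional assay on HCT-15 cells (Homo sapiens) for inhibition (on this read-out higher numbers stand for weaker inhibition and lower numbers for stronger inhibition), compound 1 gives only a limit, > 50000 nM. Compound 2 `Oc1ccc(-c2cc(-c3ccc(C(F)(F)F)cc3)cc(-c3ccccc3O)n2)cc1` differs by trifluoromethyl in place of fluoro on an aromatic carbon; in this assay compound 2 likewise gives only a limit, > 50000 nM. The step that the two limits leave unreadable from compound 1 to compound 2 therefore cannot be read. Going by the values given here, compound 3 `Oc1cccc(-c2cc(-c3ccc(OC(F)(F)F)cc3)cc(-c3ccccc3O)n2)c1` is the only member with a measured number: in this assay compound 3 gives 9410 nM, and it stands alone, as the limit of > 50000 nM in this assay, at which 2 of the 3 values shown sit, marks where the other two sit.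

Compound 4 `Oc1ccc(-c2cc(-c3ccc(OC(F)(F)F)cc3)cc(-c3ccccc3O)n2)cc1` is not yet measured. It differs from compound 3 by 4-hydroxyphenyl in place of 3-hydroxyphenyl on an aromatic carbon. Among the compounds with values here, no measured step covers this exchange of hydroxyphenyl positions; the only readable comparison, from compound 1 to compound 2, is itself unreadable between two limits. Within the data shown here, the two compounds that carry a 4-hydroxyphenyl at this place, compound 1 and compound 2, both sit at the limit, while compound 3 carries the 3-hydroxyphenyl and gives the one number, but no single-change pair ties these together.

On that basis compound 4 is expected to be weaker than compound 3, by about a 3.2-fold higher number from compound 3 to compound 4 (0.50 log units; beyond the scatter), with a real chance of another limit. The estimate for compound 4 in this assay is 30000 nM, between 8000 nM and 150000 nM.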

Compound 4, half-maximal inhibitory concentration: > 50000 nM
Compound 4: a limit, no number; the forecaster's own chance of this, stated with the estimate: 45%; middle value at least 1.6-fold (0.22 log units) from the limit.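

In this assay compound 4 gives > 50000 nM, a limit of the assay and not a number. Going by these compounds alone, with trifluoromethoxy held fixed and the same atoms joined differently, 4-hydroxyphenyl in place of 3-hydroxyphenyl at the place next to the ring nitrogen gives an at least 5.3-fold higher number from compound 3 to compound 4 (0.72 log units; beyond the scatter), the only readable step and the first sign that this position matters for inhibition in this assay. Among the compounds shown, only the one with 3-hydroxyphenyl at this place leaves the limit, while all those with 4-hydroxyphenyl there stay on it: the limit of > 50000 nM in this assay, at which 3 of the 4 values shown sit.

Going by these compounds, the steps to compound 4 from compound 1 and from compound 2 cannot be read, so what trifluoromethoxy does relative to fluoro or trifluoromethyl stays open. On these data alone, it is also open whether 3-hydroxyphenyl gives a number with fluoro or trifluoromethyl on the other ring, and how an aminophenyl or a carboxyphenyl group would compare with 3-hydroxyphenyl at this place.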